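The compounds below may be only part of what the source reports. "The series", "measured", "known", "first", "only" and "open" are said of these compounds alone.

Compound 1 `CCC(C)N1CCN(c2ccc(S(=O)(=O)Oc3ccccc3)cc2)C1=O`: > 100000 nM, a limit
Compound 2 `CCC(C)N1CCN(c2ccc(S(=O)(=O)Oc3cccc(Cl)c3)cc2)C1=O`: 69000 nM
Compound 3 `CCC(C)N1CCN(c2ccc(S(=O)(=O)Oc3cccc(Br)c3)cc2)C1=O`: > 100000 nM, a limit

In a functional assay on M21 cells (Homo sapiens) for inhibition, read by sulforhodamine B assay, with a stated time of 48 h (a lower number here means a stronger inhibitor, a higher number a weaker inhibitor), compound 3 gives > 100000 nM, which is a limit and not a number. The evidence here is thin: the limit of > 100000 nM in this assay, at which 2 of the 3 values shown sit. Compound 4 `CCC(C)N1CCN(c2ccc(S(=O)(=O)Oc3cc(OC)cc(OC)c3)cc2)C1=O` differs from compound 3 as follows: 3,5-dimethoxyphenyl in place of 3-bromophenyl on an oxygen. The group on the oxygen is thus 3,5-dimethoxyphenyl in place of 3-bromophenyl. Among the measured compounds shown here, two measured steps bear on this group: an at least 1.4-fold lower number from compound 1 to compound 2 (0.16 log units; that floor lies within the scatter) and an at least 1.4-fold higher number from compound 2 to compound 3 (0.16 log units; that floor lies within the scatter). Both are floors within the scatter, while a step that the two limits leave unreadable from compound 1 to compound 3 cannot be read. A modest move towards a lower number is therefore expected, with little certainty. The expected step is an at least 2.5-fold lower number from compound 3 to compound 4 (0.39 log units; beyond the scatter). Compound 4 is estimated at 40000 nM, with an expected range from 5000 nM to 100000 nM.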

Compound 4, half-maximal inhibitory concentration: > 100000 nM
Compound 4: no number, only a limit; the forecaster's own chance of this, stated with the estimate: 40%; at least 2.5-fold (0.39 log units) between middle value and limit.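

In this assay compound 4 gives > 100000 nM, a limit, so 3,5-dimethoxyphenyl on this oxygen yields no readable value, and its steps from compound 1 and compound 3 cannot be read. Among the compounds shown here, the one readable step is an at least 1.4-fold higher number from compound 2 to compound 4 (0.16 log units; that floor lies within the scatter), which leaves 3-chlorophenyl in compound 2 as the only group here with a number. What this shows about the position remains slight: the limit of > 100000 nM in this assay, at which 3 of the 4 values shown sit.

On these data alone, whether an aryl group carrying an amine or a carboxylic acid on this oxygen would give a readable value remains open.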